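Swapping the aniline nitrile for a methyl group

A few compounds are considered here, and "the series" means these few. Any claim that something is new, unique, unknown or untested is made for them only; others in the source may bear on it.

Three analogues sharing one core have been tested in an ADME assay on MT4 cells (Homo sapiens) for inhibition, read by MTT assay, with a stated time of 5 days; on this read-out higher numbers stand for lower toxicity in this test and lower numbers for higher toxicity in this test. Compound 1 `Cc1cccc(C)c1Oc1cc(Nc2ccc(C#N)cc2)ncc1[N+](=O)[O-]` gives 126000 nM, compound 2 `Cc1cc(C)c(Oc2cc(Nc3ccc(C#N)cc3)ncc2[N+](=O)[O-])c(C)c1` gives 69900 nM, and compound 3 `Cc1cc(C#N)cc(C)c1Oc1cc(Nc2ccc(C#N)cc2)ncc1[N+](=O)[O-]` gives 36100 nM. Compound 3 carries the lowest number of the three: the step of a 3.5-fold lower number from compound 1 to compound 3 (0.54 log units; beyond the scatter) lies beyond the scatter, whereas a 1.9-fold lower number from compound 2 to compound 3 (0.29 log units; within the scatter) does not, so compound 3 is set apart only from compound 1.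

Compound 4 `Cc1ccc(Nc2cc(Oc3c(C)cc(C#N)cc3C)c([N+](=O)[O-])cn2)cc1` differs from compound 3 as follows: methyl in place of cyano on an aromatic carbon. The nearest measured comparison is the exchange of cyano against methyl in the step of a 1.9-fold lower number from compound 2 to compound 3 (0.29 log units; within the scatter), a shift that stayed within the scatter; compound 4 reverses that exchange, although elsewhere in the structure, so the same change in the opposite direction is the guide. The step from compound 1 to compound 2, a 1.8-fold lower number from compound 1 to compound 2 (0.26 log units; within the scatter), adds that a methyl entering the structure did not move the number beyond the scatter either.

Compound 4 is therefore expected to show a step of about a 1.7-fold higher number from compound 3 to compound 4 (0.22 log units; within the scatter), toward a somewhat higher number, an estimated 60000 nM with a range from 28000 nM to 130000 nM.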

Compound 4, half-maximal cytotoxic concentration: 207000 nM
The estimate for compound 4 lay 3.5-fold (0.54 log units) below the measured number; the measured number lies above the stated range.
By their numbers in this assay, from the lowest: compounds 3, 2, 1 and 4 (each within the scatter of the next, the first and the last beyond it).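

In this assay, among these compounds, the change from 4-cyanophenyl to 4-methylphenyl gives a 5.7-fold higher number from compound 3 to compound 4 (0.76 log units; beyond the scatter) and is the first exchange of these two groups to pass beyond the scatter. The same pair of groups exchanged elsewhere in the structure, a 1.9-fold lower number from compound 2 to compound 3 (0.29 log units; within the scatter) and within the scatter, gave no such separation, so the size of this exchange depends on where it is made, at least between these two sites. No measurement shown here accounts for the size of this step.

From the compounds shown here alone, whether an amine or a carboxylic acid at this position would sit with the methyl or with the nitrile remains open. Also open, going by these compounds, is whether the same exchange would give a step of this size alongside the other substituents of compound 1 or compound 2.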